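Lengthening the nitrile chain on the shared core

A few compounds are considered here, and "the series" means these few. Any claim that something is new, unique, unknown or untested is made for them only; others in the source may bear on it.

In a functional assay on A 172 cells (Homo sapiens) for cytotoxicity, read by colorimetric assay and MTT assay (on this read-out higher numbers stand for weaker inhibition and lower numbers for stronger inhibition), compound 1 (`CCN(CC)C(=O)Cn1c(=O)c(-c2ccc(OC)cc2)cc2c(OC)cc(OC)cc21`) gives 10000 nM and compound 2 (`COc1ccc(-c2cc3c(OC)cc(OC)cc3n(CC#N)c2=O)cc1`) gives 10000 nM on the same read-out, so compound 2 stands level with compound 1. Next in line is compound 3 (`COc1ccc(-c2cc3c(OC)cc(OC)cc3n(CCCC#N)c2=O)cc1`), with this change from compound 2: 2-cyanoethyl in place of cyano on a saturated chain carbon bound to an aromatic nitrogen (2-cyanoethyl in place of cyano, which cut one bond further out reads cyanomethyl to 3-cyanopropyl). Among the compounds with values here, only one measured step bears on it: no change at the digits printed from compound 1 to compound 2 (within the scatter) at that same place. That step was a larger exchange of groups on a saturated chain carbon bound to an aromatic nitrogen, yet it moved nothing. Within the data shown here, no measured step varies the nitrile chain length, so the basis is thin. The expected step of no change at the digits printed from compound 2 to compound 3 (within the scatter) is therefore none beyond the scatter. Compound 3 is estimated at 10000 nM with an expected range from 4000 nM to 20000 nM in this assay here.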

Compound 3, half-maximal inhibitory concentration: 10000 nM
Estimate against measurement, compound 3: no gap at the digits printed; the range from low to high includes it.
By their numbers in this assay, from the lowest: compounds 1, 2 and 3 (each within the scatter of the next).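

In this assay the nitrile chain now has a second length at this place, on a saturated chain carbon bound to an aromatic nitrogen, and going from cyanomethyl to 3-cyanopropyl reads no change at the digits printed from compound 2 to compound 3 (within the scatter). Exchanging diethylcarbamoyl for 2-cyanoethyl reads no change at the digits printed from compound 1 to compound 3 (within the scatter), so all three groups now stand level in this assay, and nitrile chain length joins the exchange of group type as a change that leaves the read-out where it was. No supporting data are available to explain this flat result.

Open, on these data alone, is whether any group at this place moves the read-out beyond the scatter, for example a dialkylamine, a carboxylic acid or a chain longer than 3-cyanopropyl. Also open, as far as these compounds go, is whether replacing the methoxy groups, which all three compounds share, would change the picture.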